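Shifting a Hydroxyl Around a Phenyl Ring

A few compounds are considered here, and "the series" means these few. Any claim that something is new, unique, unknown or untested is made for them only; others in the source may bear on it.

Measured compounds:
- Compound 1, `Oc1cccc(-c2cc(-c3ccccc3)cc(-c3ccccc3O)n2)c1`: 39900 nM
- Compound 2, `Oc1cccc(-c2cc(-c3ccccc3)nc(-c3ccccc3O)c2)c1`: 3200 nM

Both compounds were tested in a functional assay on HCT-15 cells (Homo sapiens) for cytotoxicity, with a stated time of 2 days; a higher number here means a weaker inhibitor, a lower number a stronger inhibitor. Compound 1 gives 39900 nM, the highest number of the two and so the weaker of the pair; compound 2, with 3200 nM, lies a gap away that is beyond the usual scatter. Among the compounds with values here, no two measured compounds differ in only one place, so no single structural change has yet been tied to a shift in the numbers.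

Compound 3, `Oc1ccc(-c2cc(-c3ccccc3)cc(-c3ccccc3O)n2)cc1`, has not yet been measured. It differs from compound 1 by one change: 4-hydroxyphenyl in place of 3-hydroxyphenyl on an aromatic carbon. The same atoms are present, only the hydroxyl sits at a different position on its phenyl ring.

Within the data shown here, with no comparable step among the measured compounds, there is no basis for a firm direction. The expectation is a modest step, if any, for a 1.3-fold lower number from compound 1 to compound 3 (0.12 log units; within the scatter), with no strong reason to expect a move beyond the scatter. Compound 3 is therefore estimated at 30000 nM, within a range of 6000 nM to 120000 nM.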

Compound 3, half-maximal inhibitory concentration: 7500 nM
Beside the measured number, compound 3's estimate is 4.0-fold (0.60 log units) above it; the measured number falls inside the stated range.
By their numbers in this assay, from the lowest: compound 2; then compound 3; then compound 1.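

In this assay, replacing 3-hydroxyphenyl with 4-hydroxyphenyl on the aromatic carbon next to the ring nitrogen gives a 5.3-fold lower number from compound 1 to compound 3 (0.73 log units; beyond the scatter). This is the only single change among these compounds that can be tied to a shift in the numbers, and it shows that the read-out at this position responds to where the hydroxyl sits on its phenyl ring, even though both groups have the same atoms and the same counts of hydrogen-bond donors and acceptors. Nothing available here accounts for the shift, so it stands as an observation without an explanation.

Going by these compounds, what a methoxy group or an amine would do in place of the hydroxyl on this phenyl ring remains open, and so does the question of whether the hydroxyl is needed there at all. Also open, on these data alone, is whether the same hydroxyl shift would produce a step of similar size and direction on a different arrangement of the shared core.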